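Working notes on the nitro-to-phenyl change in one series

A few compounds are considered here, and "the series" means these few. Any claim that something is new, unique, unknown or untested is made for them only; others in the source may bear on it.

Values so far in a functional assay on Raji cells (Homo sapiens) for cytotoxicity, read by CCK-8 assay, with a stated time of 24 h; on this read-out lower numbers stand for stronger inhibition and higher numbers for weaker inhibition:
Compound 1 `C=CC(=O)N1C(=O)CC(c2ccc([N+](=O)[O-])cc2)Sc2ccccc21` gives 34800 nM.
Compound 2 `C=CC(=O)N1C(=O)CC(c2ccc(C)cc2)Sc2ccccc21` gives 75500 nM.
Compound 3 `C=CC(=O)N1C(=O)CC(c2ccc(OC)cc2)Sc2ccccc21` gives 43300 nM.

Compound 1 holds the lowest number of the three in this assay. Its nearest neighbour is compound 3, and the step of a 1.2-fold higher number from compound 1 to compound 3 (0.09 log units; within the scatter) lies within the scatter, so the two cannot be ordered. Against compound 2 the step of a 2.2-fold higher number from compound 1 to compound 2 (0.34 log units; beyond the scatter) goes beyond the scatter. Between the other two, the step of a 1.7-fold lower number from compound 2 to compound 3 (0.24 log units; within the scatter) again stays within the scatter, so the whole measured spread is narrow.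

Compound 4 `C=CC(=O)N1C(=O)CC(c2ccc(-c3ccccc3)cc2)Sc2ccccc21` differs from compound 1 in one place: phenyl in place of nitro on an aromatic carbon. Within the data shown here, no measured pair brings in a phenyl at this position, so the only steps that bear on the change are the two that likewise remove the nitro from compound 1, one modest and beyond the scatter, the other within it. Both point to a higher number in this assay, and nothing measured points the other way. The expectation for compound 4 is therefore a small rise, possibly none beyond the scatter, with the step of a 1.6-fold higher number from compound 1 to compound 4 (0.20 log units; within the scatter) as the expected size. Compound 4 is estimated at 55000 nM, with a range from 22000 nM to 140000 nM.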

Compound 4, half-maximal inhibitory concentration: 56300 nM
The estimate for compound 4 lay 1.0-fold (0.01 log units) below the measured number, and the stated range covers the measured number.
By their numbers in this assay, from the lowest: compounds 1, 3, 4 and 2 (each within the scatter of the next, the first and the last beyond it).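

In this assay, a whole aromatic ring at this place, para to a large group, cannot be told from the nitro of the starting compound, with a 1.6-fold higher number from compound 1 to compound 4 (0.21 log units; within the scatter), from the methoxy, with a 1.3-fold higher number from compound 3 to compound 4 (0.11 log units; within the scatter), or from the methyl, with a 1.3-fold lower number from compound 2 to compound 4 (0.13 log units; within the scatter). Among these compounds, all three steps lie within the scatter, so compound 4 cannot be ordered against any other compound, and compound 1 and compound 2 remain the only pair separated, even though the phenyl brings more heavy atoms and a ring and, unlike the nitro, no hydrogen-bond acceptors. No measurement at hand bears on why the four numbers stay so close.

Still open, going by these compounds, is whether any group at this place can move the number clearly out of this narrow spread, for instance an amine, a carboxylic acid, a fluorine or chlorine atom, or a longer chain. On these data alone, all four compounds also share the rest of the core of compound 1, so the part played by the acryloyl group, for example against a saturated propanoyl group, remains unknown.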